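Sulfonyl groups in place of the amide arm on the shared core

The source may hold more compounds than are shown below. What is called first, only, known or untested is meant among the compounds shown, and "the series" means these compounds.

Measured compounds:
compound 1 `CC(C)NC(=O)CN1CCN(c2ccc(OCC3CCN(C(=O)OC(C)C)CC3)cn2)CC1`: > 10000 nM
compound 2 `CCS(=O)(=O)N1CCN(c2ccc(OCC3CCN(C(=O)OC(C)C)CC3)cn2)CC1`: 1300 nM
compound 3 `CCCCS(=O)(=O)N1CCN(c2ccc(OCC3CCN(C(=O)OC(C)C)CC3)cn2)CC1`: 100 nM

All three share one core and differ only in the group on the ring amine nitrogen. In a functional assay on CHO-K1 cells for agonist activity at Glucose-dependent insulinotropic receptor (Homo sapiens), read by a luciferase reporter, with a stated time of 5 h (a lower number here means that less compound is needed, a higher number that more compound is needed for the effect), compound 1 gives > 10000 nM, which is a limit of the assay and not a number (the limit of > 10000 nM in this assay, at which 1 of the 3 values shown sits). Compound 2, with ethylsulfonyl on that nitrogen, gives 1300 nM in this assay, and compound 3, with butylsulfonyl, gives 100 nM. The steps of an at least 7.6-fold lower number from compound 1 to compound 2 (0.88 log units; beyond the scatter) and an at least 100-fold lower number from compound 1 to compound 3 (2.00 log units; beyond the scatter) show that either sulfonyl lowers the number beyond the scatter, and a 13-fold lower number from compound 2 to compound 3 (1.11 log units; beyond the scatter) shows that the longer chain lowers it further still.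

Compound 4 `CC(C)OC(=O)N1CCC(COc2ccc(N3CCN(S(=O)(=O)N4CCCCC4)CC3)nc2)CC1` is not yet measured in this assay. It differs from compound 1 thus: (piperidin-1-yl)sulfonyl in place of (isopropylcarbamoyl)methyl on an amine nitrogen in a ring. The entering group is a sulfonyl of the same kind as those of compounds 2 and 3, with a six-membered ring on the sulfur where compound 3 carries a butyl chain. The two steps from compound 1 to the sulfonyls bear directly on this change; both were at least modest to large. A step of the same kind, toward a lower number, is therefore expected, an at least 50-fold lower number from compound 1 to compound 4 (1.69 log units; beyond the scatter). Compound 4 is expected to give about 200 nM in this assay, within 50 nM to 1000 nM.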

Compound 4, half-maximal effective concentration: 1000 nM
Beside the measured number, compound 4's estimate is 5.0-fold (0.70 log units) below it; measured number inside the range.
By their numbers in this assay, from the lowest: compound 3; then compounds 4 and 2 (each within the scatter of the next). At a limit, above all of these: compound 1.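

In this assay, (piperidin-1-yl)sulfonyl in place of the amide arm gives an at least 10-fold lower number from compound 1 to compound 4 (1.00 log units; beyond the scatter), so the gain at this amine nitrogen in a ring also holds for a sulfonyl carrying a ring on the sulfur. That step is only a bound, as compound 1 stands at a limit of the assay and not at a number: the limit of > 10000 nM in this assay, at which 1 of the 4 values shown sits.

The group on the sulfur also counts: piperidin-1-yl in place of butyl gives a 10-fold higher number from compound 3 to compound 4 (1.00 log units; beyond the scatter), whereas piperidin-1-yl in place of ethyl gives a 1.3-fold lower number from compound 2 to compound 4 (0.11 log units; within the scatter), so the ring keeps none of the gain seen with the butyl chain and leaves compound 4 level with compound 2.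

The compounds shown do not separate the effect of the ring from that of the nitrogen bonded to the sulfur; cyclohexyl on the sulfur, or an open diethylamino group, would pull the two apart. Nor do they show whether the gain from ethyl to butyl continues with a longer chain such as hexyl.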